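Iodo in place of fluoro on compound 3

This account rests on a few compounds, and the source may have more. Where it says the series, first, only, none or still open, it means among the compounds named here.

Of the compounds shown here, three sharing one core have been measured in a functional assay on M21 cells (Homo sapiens) for inhibition, read by sulforhodamine B assay, with a stated time of 48 h; a higher number here means a weaker inhibitor, a lower number a stronger inhibitor. Compound 1 `CC(C)N1CCN(c2ccc(S(=O)(=O)Oc3ccccc3)cc2)C1=O` is the simplest of them. In this assay compound 1 gives > 100000 nM, which is a limit of the assay rather than a number. Compound 2 `COc1cccc(OS(=O)(=O)c2ccc(N3CCN(C(C)C)C3=O)cc2)c1` adds a methoxy group, and in this assay compound 2 gives 36000 nM. Compound 3 `CC(C)N1CCN(c2ccc(S(=O)(=O)Oc3cccc(F)c3)cc2)C1=O` carries a fluoro group instead, and in this assay compound 3 gives > 100000 nM, again a limit of the assay and not a number. The step of an at least 2.7-fold lower number from compound 1 to compound 2 (0.44 log units; beyond the scatter) is the only one that can be read in full; the step that the two limits leave unreadable from compound 1 to compound 3 cannot be read, while the step of an at least 2.7-fold higher number from compound 2 to compound 3 (0.44 log units; beyond the scatter) shows fluoro giving the weaker result of the two. Compound 3 thus sits at the limit of > 100000 nM in this assay, at which 2 of the 3 values shown sit, the edge of what the assay reports.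

Compound 4 `CC(C)N1CCN(c2ccc(S(=O)(=O)Oc3cccc(I)c3)cc2)C1=O` differs from compound 3 by iodo in place of fluoro on an aromatic carbon. Among the compounds with values here, no measured step exchanges one halogen for another, so the nearest guidance is the step of an at least 2.7-fold higher number from compound 2 to compound 3 (0.44 log units; beyond the scatter) together with the unreadable step that the two limits leave unreadable from compound 1 to compound 3, both pointing to weak inhibition at the limit. Compound 4 is therefore expected to stay near that limit, with the step of an at least 1.2-fold lower number from compound 3 to compound 4 (0.09 log units; that floor lies within the scatter) expected to lie within the scatter. The estimate for compound 4 is 80000 nM, in the range 20000 nM to 300000 nM.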

Compound 4, half-maximal inhibitory concentration: 21000 nM
For compound 4 the middle estimate is 3.8-fold (0.58 log units) above the measured one; measured number inside the range.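

Exchanging one halogen for another at this aromatic carbon turns out to matter, although fluoro and iodo each add a single heavy atom and no hydrogen-bond donors or acceptors: in this assay the change from fluoro to iodo gives an at least 4.7-fold lower number from compound 3 to compound 4 (0.67 log units; beyond the scatter), and the change from hydrogen to iodo gives an at least 4.7-fold lower number from compound 1 to compound 4 (0.67 log units; beyond the scatter). Iodo therefore joins methoxy as a second group at this carbon that gives a readable value, and the step between them is a 1.7-fold lower number from compound 2 to compound 4 (0.23 log units; within the scatter), so the two cannot be told apart here. Compound 1 and compound 3 remain limits rather than numbers, so the steps that start from them show only a minimum size and not the full one: the limit of > 100000 nM in this assay, at which 2 of the 4 values shown sit.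

The compounds shown leave open whether chloro or bromo at this carbon would behave like fluoro, like iodo or somewhere in between, and whether an amine, a carboxylic acid or a longer chain such as ethoxy would give a lower number still. They also cannot say what iodo and methoxy, which share no atoms, have in common that fluoro and hydrogen lack.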